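This account rests on a few compounds, and the source may have more. Where it says the series, first, only, none or still open, it means among the compounds named here.

Within the data shown here, compound 1 `CCC[C@@H]1O[C@H](COCc2ccccc2)[C@@H](OCc2ccccc2)[C@H](OCc2ccccc2)[C@H]1O` is the only member of this small set that returns a number: in a functional assay on HL-60 cells (Homo sapiens) for antiproliferative activity, read by MTT assay (a lower number here means a stronger inhibitor, a higher number a weaker inhibitor), compound 1 gives 11700 nM, a weak result. Among the measured compounds shown here, compound 2 `O[C@@H]1[C@@H](OCc2ccccc2)[C@H](OCc2ccccc2)[C@@H](COCc2ccccc2)O[C@H]1CC1CC1` stands differently: in this assay compound 2 gives "not active" (no number reported), so no single value can be placed for it, and no step between compound 1 and compound 2 can be sized beyond noting that one is weak and the other without a reported number. Compound 3 `O[C@@H]1[C@@H](OCc2ccccc2)[C@H](OCc2ccccc2)[C@@H](COCc2ccccc2)O[C@H]1Cc1ccccc1` is the next entry to be measured in this assay. It differs from compound 2 by phenyl in place of cyclopropyl on a saturated chain carbon bound to a saturated ring carbon. For the measured compounds named here, with compound 2 lacking a number, no step from compound 2 to compound 3 can be sized; what can be said is that compound 1, the closest measured neighbour with a value, sits at 11700 nM, and both known points lie at the weak end. For compound 3 the expectation is a weak or absent result, estimated at 20000 nM with a range of 5000 nM to 80000 nM, and a fair chance that this assay again reports no number.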

Compound 3, half-maximal inhibitory concentration: 8700 nM
Estimate against measurement, compound 3: 2.3-fold (0.36 log units) above; the measured number falls inside the stated range.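

In this assay compound 3 gives 8700 nM as a measured number, so phenyl on a saturated chain carbon bound to a saturated ring carbon keeps a readable result, whereas compound 2, with cyclopropyl at that place, has no number and its step to compound 3 cannot be read. Phenyl in place of ethyl at this place gives a 1.3-fold lower number from compound 1 to compound 3 (0.13 log units; within the scatter) and lies within the scatter, so these two groups cannot be told apart in this assay and both compounds remain weak. No measurement shown here offers an explanation for these readings.

From the compounds shown here alone, whether an amine or a carboxylic acid at this place, or a longer chain ending in phenyl, would shift the value beyond the scatter remains open. Also open, going by these compounds, is how a fluorine or a methoxy group on the phenyl would read on the shared core.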